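From a Urea Chain to a Trifluoromethylphenyl Amide

A few compounds are considered here, and "the series" means these few. Any claim that something is new, unique, unknown or untested is made for them only; others in the source may bear on it.

Compound 1 `O=C(NCCCCCCCl)Nc1c(C(O)(C(F)(F)F)C(F)(F)F)ccc2ccccc12` carries a (6-chlorohexyl)amino group on its carbonyl carbon, and in an assay on LtK cells with ATP-sensitive inward rectifier potassium channel 11 (Homo sapiens) as the target (a lower number here means that less compound is needed, a higher number that more compound is needed for the effect), compound 1 gives 4840 nM, the highest of the three numbers measured. Compound 2 `O=C(Nc1c(C(O)(C(F)(F)F)C(F)(F)F)ccc2ccccc12)c1ccc(F)cc1`, which carries a 4-fluorophenyl group in that place, gives 70 nM in this assay, and compound 3 `Cc1ccc(C(=O)Nc2c(C(O)(C(F)(F)F)C(F)(F)F)ccc3ccccc23)cc1`, with a 4-methylphenyl group there, gives 76 nM. The two measured steps, a 69-fold lower number from compound 1 to compound 2 (1.84 log units; beyond the scatter) and a 64-fold lower number from compound 1 to compound 3 (1.80 log units; beyond the scatter), agree closely in size and direction, while the step of a 1.1-fold higher number from compound 2 to compound 3 (0.04 log units; within the scatter) shows that the fluoro and methyl variants cannot be told apart.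

Compound 4 `O=C(Nc1c(C(O)(C(F)(F)F)C(F)(F)F)ccc2ccccc12)c1ccc(C(F)(F)F)cc1` differs from compound 1 in one place: 4-(trifluoromethyl)phenyl in place of (6-chlorohexyl)amino on a carbonyl carbon. Both measured steps bear directly on this change, since each also replaces the same chain on the carbonyl carbon with a phenyl ring that carries one further group. The account therefore expects a large step in the same direction, a 54-fold lower number from compound 1 to compound 4 (1.73 log units; beyond the scatter), for compound 4. Compound 4 is estimated at 90 nM in this assay, with a range from 30 nM to 300 nM. Within the data shown here, this expectation rests on compound 2 at 70 nM and on compound 3 at 76 nM, the only aromatic analogues measured so far.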

Compound 4, half-maximal effective concentration: 160 nM
Compound 4: the middle estimate sits 1.8-fold (0.25 log units) below what was measured; the measured number falls inside the stated range.
By their numbers in this assay, from the lowest: compounds 2 and 3 (each within the scatter of the next); then compound 4; then compound 1.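

The trifluoromethyl compound keeps most of the gain seen with the other aromatic groups in this assay, with a 30-fold lower number from compound 1 to compound 4 (1.48 log units; beyond the scatter), so the drop from compound 1 now holds across all three substituted phenyl rings shown. Among these compounds, it also shows for the first time that the group on the aromatic carbon can change the number. Fluoro and methyl could not be told apart, but trifluoromethyl gives a 2.1-fold higher number from compound 3 to compound 4 (0.32 log units; beyond the scatter) and a 2.3-fold higher number from compound 2 to compound 4 (0.36 log units; beyond the scatter), two modest steps in the same direction that make compound 4 the aromatic analogue needing more compound than either compound 2 or compound 3. Nothing in the data shown accounts for this difference.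

The compounds shown leave open how an unsubstituted phenyl ring, or a methoxy group, an amine or a carboxylic acid on that aromatic carbon, would compare with these three. They also leave open how much of the large drop belongs to the ring itself and how much to the loss of the urea nitrogen, since each step from compound 1 changes both at once, and a shorter chain or a phenylamino group on the carbonyl carbon would bear on that question.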